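A few compounds are considered here, and "the series" means these few. Any claim that something is new, unique, unknown or untested is made for them only; others in the source may bear on it.

Working notes, series of compounds sharing the core of compound 2 `N=C(N)NCCC[C@H](NC(=O)CN(c1nc(Cl)nc2[nH]cnc12)C1CC1)C(=O)O`. In a functional assay on the whole organism (Tail, strain ICR) with Mus musculus as the target, in the tail flick test, with a stated time of 60 min, at a dose of 25 umol/kg by the oral route (on this read-out higher numbers stand for a stronger effect at the one dose given and lower numbers for a weaker effect), compound 2 gives 51%, the highest of the three numbers in hand. For the measured compounds named here, compound 1 `O=C(O)[C@@H]1CCCN1C(=O)CN(c1nc(Cl)nc2[nH]cnc12)C1CC1` gives 34.9%, and compound 3 `N=C(N)NCCC[C@H](NC(=O)CN(c1nc(Cl)nc2[nH]cnc12)C1CC1)C(=O)OCc1ccccc1` gives 30.6%; the one step between neighbours, a number 20.4 percentage points lower from compound 2 to compound 3 (beyond the scatter), concerns the oxygen next to the carbonyl, not the chain carbon. Compound 4 `O=C(CN(c1nc(Cl)nc2[nH]cnc12)C1CC1)N[C@@H](CO)C(=O)O` differs from compound 2 by one oxygen atom in place of a group of 6 heavy atoms (3 carbon, 3 nitrogen; no ring), on a saturated chain carbon, two bonds along the chain from an amide-type nitrogen and a carbonyl carbon. Going by the values given here, no measured step touches that position, so no size is known for this kind of change; the spread among the measured compounds gives only a rough scale. A value near compound 1 is expected, with compound 4 estimated at 35% (range 20% to 50%), a step of a number 16 percentage points lower from compound 2 to compound 4 (beyond the scatter) expected, likely beyond the scatter.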

Compound 4, a percentage reported as activity, at one dose (the size of the read-out at that dose, not a potency): 39.8%
Beside the measured number, compound 4's estimate is 4.8 percentage points below it; measured number inside the range.
By their numbers in this assay, from the lowest: compounds 3, 1 and 4 (each within the scatter of the next); then compound 2.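

At the saturated chain carbon, two bonds along the chain from an amide-type nitrogen and a carbonyl carbon, this assay now gives a first size: hydroxy in place of the group of 6 heavy atoms gives a number 11.2 percentage points lower from compound 2 to compound 4 (beyond the scatter). That group is therefore not required for a response at this dose. (1-Carboxy-2-hydroxyethyl)amino in place of 2-carboxypyrrolidin-1-yl on a carbonyl carbon gives a number 4.9 percentage points higher from compound 1 to compound 4 (within the scatter), so these two compounds do not separate. No evidence is available to explain either step. Open, as far as these compounds go, is whether a simple amine or a longer chain at this carbon would match compound 2.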